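From methoxy to ethoxy on the shared core

The source may hold more compounds than are shown below. What is called first, only, known or untested is meant among the compounds shown, and "the series" means these compounds.

Measured in a physicochemical assay for solubility, at pH 7.4; a lower number here means a less soluble compound, a higher number a more soluble compound:
- compound 1 `CCOC(=O)c1c(-c2cccc(-c3ccccc3)c2)[nH]c2cc(OC)ccc2c1=O`: 200 nM
- compound 2 `CCOC(=O)c1c(-c2cccc(OC)c2)[nH]c2cc(OC)ccc2c1=O`: 74000 nM

Of these two, compound 2 has the higher number, at 74000 nM. Compound 3 `CCOC(=O)c1c(-c2cccc(OCC)c2)[nH]c2cc(OC)ccc2c1=O` extends its methoxy to ethoxy, with methyl in place of hydrogen on a saturated chain carbon bound to an oxygen on an aromatic ring. Going by the values given here, only one measured step bears on this change: a 370-fold higher number from compound 1 to compound 2 (2.57 log units; beyond the scatter), which put methoxy in place of phenyl. That single large step exchanged far more than one methyl, so only a small part of its size is expected here, and the direction rests on this one step alone. The number is expected to fall slightly in this assay, towards that of compound 1. The estimated change is a 2.1-fold lower number from compound 2 to compound 3 (0.33 log units; beyond the scatter). For compound 3 the expected value is 35000 nM, with an estimated range of 10000 nM to 90000 nM.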

Compound 3, solubility: 8700 nM
Beside the measured number, compound 3's estimate is 4.0-fold (0.60 log units) above it; measured number below the stated range.
By their numbers in this assay, from the lowest: compound 1; then compound 3; then compound 2.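

In this assay the methyl that turns methoxy into ethoxy is not a silent change: the result is an 8.5-fold lower number from compound 2 to compound 3 (0.93 log units; beyond the scatter) and lies beyond the scatter, so this saturated chain carbon bound to an oxygen on an aromatic ring responds to a single added methyl. Ethoxy still keeps most of the gain over phenyl, with a 44-fold higher number from compound 1 to compound 3 (1.64 log units; beyond the scatter) against the earlier 370-fold higher number from compound 1 to compound 2 (2.57 log units; beyond the scatter) for methoxy, and so the three groups rank phenyl, ethoxy, methoxy from the lowest number. Nothing given here says what lies behind the size of these steps.

Going by these compounds, whether a longer chain such as propoxy would lower the number further remains open. So does the outcome of an amine or a carboxylic acid at the end of this chain, or of a plain hydroxyl in place of the methoxy.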